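Extending the para substituent on the aryl ether of compound 1

The compounds below may be only part of what the source reports. "The series", "measured", "known", "first", "only" and "open" are said of these compounds alone.

Measured compounds:
compound 1 `Cc1ccc(Oc2cccc(COc3ccccc3CCC(=O)OCCCOP(=O)(O)OC[C@H](N)C(=O)O)c2)cc1` — 18.2%
compound 2 `N[C@@H](COP(=O)(O)OCCCOC(=O)CCc1ccccc1OCc1cccc(Oc2ccc(Cl)c(Cl)c2)c1)C(=O)O` — 18%

In an assay on cells for agonist activity at probable G-protein coupled receptor 34 (Mus musculus), with a stated time of 1 h (on this read-out higher numbers stand for larger maximal responses and lower numbers for smaller maximal responses), compound 1 gives 18.2% and compound 2 gives 18%; a number 0.2 percentage points lower from compound 1 to compound 2 (within the scatter). Compound 1 thus stands highest of the two numbers, though not apart from compound 2. Compound 3 `Cc1ccccc1-c1ccc(Oc2cccc(COc3ccccc3CCC(=O)OCCCOP(=O)(O)OC[C@H](N)C(=O)O)c2)cc1` differs from compound 1 by 2-methylphenyl in place of methyl on an aromatic carbon. Among the compounds with values here, the only measured step changes a different group, so nothing measured bears on this change; it was within the scatter, so no step beyond the scatter is expected in this assay. Compound 3 is estimated at 18% (range 8% to 32%), a step of a number 0.2 percentage points lower from compound 1 to compound 3 (within the scatter).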

Compound 3, largest response reached (Emax), in percent of the reference or control that the assay uses: 13.4%
Estimate against measurement, compound 3: 4.6 percentage points above; the measured number falls inside the stated range.
By their numbers in this assay, from the lowest: compounds 3, 2 and 1 (each within the scatter of the next).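

At this aromatic carbon, para to a large group, 2-methylphenyl, with its 7 heavy atoms and one six-membered aromatic ring, takes the place of methyl, and this assay shows a number 4.8 percentage points lower from compound 1 to compound 3 (within the scatter). The position therefore accepts a much larger group, including an added aromatic ring, without a step beyond the scatter. No available evidence accounts for this result.

Going by these compounds, whether an amine, a carboxylic acid or a longer alkyl chain at this carbon would also stay within the scatter remains open. So does whether any group here can produce a step beyond it.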